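Aryl-triazole coumarin series: cytotoxicity notes toward compound 4

The compounds below may be only part of what the source reports. "The series", "measured", "known", "first", "only" and "open" are said of these compounds alone.

Measured compounds:
compound 1 `Cc1cc(=O)oc2cc(OCc3cn(-c4ccc(F)c(Cl)c4)nn3)ccc12`; in an ADME assay on Huh-7 cells (Homo sapiens) for cytotoxicity, read by MTT assay, with a stated time of 72 h (on this read-out higher numbers stand for lower toxicity in this test and lower numbers for higher toxicity in this test), compound 1 reports only a limit, > 100 ug/mL.
compound 2 `Cc1cc(=O)oc2cc(OCc3cn(-c4ccc(F)cc4)nn3)ccc12`; in this assay compound 2 reports only a limit, > 100 ug/mL.
compound 3 `Cc1cc(=O)oc2cc(OCc3cn(-c4ccc(Cl)cc4)nn3)ccc12`; in this assay compound 3 reports only a limit, > 100 ug/mL.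

Among the compounds with values here, compound 3 therefore stands where the other two stand: at a limit of this assay rather than at a number, and the same holds for every value so far (the limit of > 100 ug/mL in this assay, at which 3 of the 3 values shown sit). The measured steps give no readable size: a step that the two limits leave unreadable from compound 1 to compound 2, a step that the two limits leave unreadable from compound 1 to compound 3 and a step that the two limits leave unreadable from compound 2 to compound 3 are all closed off by the limit on both sides.

Compound 4 `Cc1cc(=O)oc2cc(OCc3cn(-c4ccc(OC(F)(F)F)cc4)nn3)ccc12` differs from compound 3 in one place: trifluoromethoxy in place of chloro on an aromatic carbon. Within the data shown here, no measured step bears on this change in a readable way, so no step beyond the scatter is expected in either direction. The step of a number no higher from compound 3 to compound 4 (the limit leaves the size open) is estimated as essentially none. Compound 4 is accordingly expected in this assay at about 100 ug/mL, within 50 ug/mL to 200 ug/mL, most likely again reported only as a limit.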

Compound 4, half-maximal cytotoxic concentration: > 100 ug/mL
Compound 4 was reported as a limit; the forecaster's own chance of this, stated with the estimate: 80%; the middle value lies on the limit itself.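

No new step can be read between compound 4 and compound 2 or compound 3, as all four compounds stand at one limit: the limit of > 100 ug/mL in this assay, at which 4 of the 4 values shown sit. The compounds shown leave open how far any of them lies beyond that limit, and whether any aryl substituent changes cytotoxicity at all.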